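The source may hold more compounds than are shown below. What is called first, only, known or untested is meant among the compounds shown, and "the series" means these compounds.

Measured so far:
compound 1, `COc1cc(/C=C/C(=O)O)ccc1OC(=O)c1nc(C)c(C)nc1C`: 55.4%
compound 2, `CCOC(=O)/C=C/c1ccc(OC(=O)c2nc(C)c(C)nc2C)c(O)c1`: 375%
compound 3, `Cc1nc(C)c(C(=O)Oc2ccc(/C=C/C(=O)O)cc2)nc1C`: 93.2%

In a functional assay on EA.hy 926 cells (Homo sapiens) for cytotoxicity, read by MTT assay, with stated times of 24 h and 12 h, tested at 100 uM (on this read-out higher numbers stand for a stronger effect at the one concentration tested and lower numbers for a weaker effect), compound 3 gives 93.2%, the second highest of the three numbers; compound 1 sits lower at 55.4% and compound 2 far higher at 375%. Among the compounds with values here, only one step has been measured, a number 37.8 percentage points higher from compound 1 to compound 3 (beyond the scatter), and it shows that taking a methoxy group off an aromatic carbon raised the read-out well beyond the scatter.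

Compound 4, `Cc1nc(C)c(C(=O)Oc2ccc(/C=C/C(=O)O)cc2O)nc1C`, differs from compound 3 by hydroxy in place of hydrogen on an aromatic carbon. Within the data shown here, no measured step adds a hydroxy group, so this change has no direct parallel. Compound 2 also carries a hydroxy group and gives 375%, but it differs from compound 3 in more than one place, so its number can only hint. A rise rather than no change is expected because a number 37.8 percentage points higher from compound 1 to compound 3 (beyond the scatter) shows that a single change on this ring can move this assay well beyond the scatter. For compound 4 the expected value is 130%, within 60% to 260%. That corresponds to an expected step of a number 36.8 percentage points higher from compound 3 to compound 4 (beyond the scatter).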

Compound 4, a percentage reported as activity, at one concentration (the size of the read-out at that concentration, not a potency): 601%
For compound 4 the middle estimate is 471 percentage points below the measured one, outside the stated range (above it).
By their numbers in this assay, from the lowest: compound 1; then compound 3; then compound 2; then compound 4.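

In this assay, the hydroxy group on this aromatic carbon, ortho to a large group, goes with a very large rise: a number 507.8 percentage points higher from compound 3 to compound 4 (beyond the scatter) when it replaces hydrogen, and a number 545.6 percentage points higher from compound 1 to compound 4 (beyond the scatter) when hydrogen replaces the methyl of the methoxy group at the same place, so an oxygen here is not enough and the free hydroxy group gives the higher number. The other end of the molecule matters as well, since with this hydroxy group kept, removing the ethyl from the ester gives a number 226 percentage points higher from compound 2 to compound 4 (beyond the scatter) and the hydroxy group alone does not set the value. Nothing available explains why these changes have such large effects.

From the compounds shown here alone, it remains open whether an amine or a fluorine atom at this place would match the hydroxy group. A longer chain on that oxygen is equally unresolved.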